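Methoxy in place of hexylamino on a carbonyl carbon

The compounds below may be only part of what the source reports. "The series", "measured", "known", "first", "only" and "open" are said of these compounds alone.

In a functional assay on HCT-116 cells (Homo sapiens) for antiproliferative activity (on this read-out higher numbers stand for weaker inhibition of growth and lower numbers for stronger inhibition of growth), compound 1 (`CCCCCCNC(=O)c1cc(C#Cc2cc(OC)ccc2OC)ccc1OC`) gives 6900 nM and compound 2 (`CCCCCCNC(=O)c1cc(/C=C\c2cc(OC)ccc2OC)ccc1OC`) gives 21100 nM so compound 1 holds the lower of the two numbers, by a gap beyond the scatter. Compound 3 (`COC(=O)c1cc(C#Cc2cc(OC)ccc2OC)ccc1OC`) carries methoxy in place of hexylamino on a carbonyl carbon. Within the data shown here, no measured pair shows this change, so the step can only be judged from the structures. A small move toward weaker inhibition of growth is expected in this assay (estimated step a 2.3-fold higher number from compound 1 to compound 3 (0.37 log units; beyond the scatter)). Compound 3 is estimated at 16000 nM (expected range 4000 nM to 60000 nM).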

Compound 3, concentration for 50% growth inhibition: 37700 nM
For compound 3 the middle estimate is 2.4-fold (0.37 log units) below the measured one; measured number inside the range.
By their numbers in this assay, from the lowest: compound 1; then compounds 2 and 3 (each within the scatter of the next).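

In this assay, methoxy in place of hexylamino on the carbonyl carbon gives a 5.5-fold higher number from compound 1 to compound 3 (0.74 log units; beyond the scatter) and so shows that this position affects growth inhibition, which compounds 1 and 2 could not show since both carry hexylamino. Within this pair, the hexylamino amide is the better of the two groups. No measured property explains the step.

The change removes the amide hydrogen and the hexyl chain together, and this single pair cannot separate the two. A butylamino or octylamino group, or a carboxylic acid on the same carbonyl carbon, would bear on that question.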